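Methyl in Place of Bromo: From Compound 3 to Compound 4

The source may report more compounds than this note shows. Statements on the series, on what has been measured and on what is new or still open speak of the compounds shown alone.

Compound 3 `Oc1nc2cc(Br)ccc2n1C1CCN(CC2COc3ccccc3O2)CC1` gives 20 mg/kg in a functional assay on the whole organism with Rattus norvegicus as the target (on this read-out lower numbers stand for an effect already at smaller amounts and higher numbers for an effect only at larger amounts of compound), the highest of the two numbers shown. Its nearest neighbour is compound 1 `Cc1cccc2c1OCC(CN1CCC(n3c(O)nc4cc(F)ccc43)CC1)O2`, which gives 8 mg/kg in this assay, a gap beyond the usual scatter. Compound 2 `Oc1nc2cc(F)ccc2n1C1CCN(CC2COc3cc(F)ccc3O2)CC1` reaches only the limit of < 5 mg/kg in this assay, which is a limit and not a number (the limit of < 5 mg/kg in this assay, at which 1 of the 3 values shown sits). Compound 4 `Cc1ccc2c(c1)nc(O)n2C1CCN(CC2COc3ccccc3O2)CC1` differs from compound 3 by methyl in place of bromo on an aromatic carbon. Among the measured compounds shown here, no measured pair shows this change on its own, so its effect is uncertain; a small shift in this assay toward lower numbers, not larger than the scatter, seems most likely. Compound 4 is therefore expected to give about 15 mg/kg (range 5 mg/kg to 40 mg/kg), an expected step of a 1.3-fold lower number from compound 3 to compound 4 (0.12 log units; within the scatter).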

Compound 4, dose for half-maximal effect: 40 mg/kg
Compound 4: middle estimate off by 2.7-fold (0.43 log units), on the low side; low and high end bracket the measured number.
By their numbers in this assay, from the lowest: compound 1; then compounds 3 and 4 (each within the scatter of the next). At a limit, below all of these: compound 2.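

Methyl in place of bromo on an aromatic carbon gives a 2.0-fold higher number from compound 3 to compound 4 (0.30 log units; within the scatter) in this assay, the first reading of a change at this position on its own. Bromo and methyl, each a single heavy atom, are thus not told apart here by this read-out. Nothing measured bears on this step.

From the compounds shown here alone, it remains open whether a group of another kind at this position, such as an amine, a methoxy or a carboxylic acid, would produce a step beyond the scatter. Going by these compounds, whether methyl and bromo stay this close with a different group on the other side of the molecule also remains open.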